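Inverting One Stereocentre at the Assay Limit

The source may hold more compounds than are shown below. What is called first, only, known or untested is meant among the compounds shown, and "the series" means these compounds.

Compound 1 `CC[C@@H]1C[C@H](O)C/C=C(/C)[C@H]2c3cc(OCc4ccccc4)c(OCc4ccccc4)cc3CCN12` was tested in a functional assay on DU-145 cells (Homo sapiens) for inhibition, read by MTT assay, with a stated time of 24 h; on this read-out higher numbers stand for weaker inhibition and lower numbers for stronger inhibition. There, compound 1 gives > 20000 nM, which is a limit of the assay and not a number. Compound 2 `CCC[C@@H]1C[C@H](O)C/C=C(/CC)[C@H]2c3cc(OCc4ccccc4)c(OCc4ccccc4)cc3CCN12`, which was tested the same way, gives > 20000 nM, and this too is a limit. The picture so far is therefore (the limit of > 20000 nM in this assay, at which 2 of the 2 values shown sit).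

Compound 3 `CC[C@@H]1C[C@@H](O)C/C=C(/C)[C@H]2c3cc(OCc4ccccc4)c(OCc4ccccc4)cc3CCN12` has not yet been measured. Its relation to compound 1 is simple: the two compounds have the same atoms and bonds and differ only in configuration as drawn: 1 of 4 stereo elements differ; a stereocentre at a saturated ring carbon is drawn R in compound 1 and S in compound 3. Nothing leaves and nothing enters, and a stereocentre at a saturated ring carbon is drawn R in compound 1 and S in compound 3.

Going by the values given here, no measured step is available to show how large such a change might be. The expectation rests on compound 1, whose result of > 20000 nM is a limit. In this assay, no step beyond the usual scatter is expected, and the estimated step is a number no higher from compound 1 to compound 3 (the limit leaves the size open). Another limit is the most likely report, though a measurable number cannot be ruled out. Compound 3 is estimated at 20000 nM, with an expected range from 8000 nM to 40000 nM.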

Compound 3, half-maximal inhibitory concentration: > 20000 nM
Compound 3: only a limit was reported; the forecaster's own chance of this, stated with the estimate: 75%; the middle value sits exactly at the limit.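

No step can be read between compound 1 and compound 3, because both results are limits of the assay and not numbers: the limit of > 20000 nM in this assay, at which 3 of the 3 values shown sit. The compounds shown leave open how strongly any of them would inhibit in this assay, and whether the configuration at this saturated ring carbon matters for inhibition at all.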